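A few compounds are considered here, and "the series" means these few. Any claim that something is new, unique, unknown or untested is made for them only; others in the source may bear on it.

Compound 2 `CC(C)c1n[nH]c2c(NCc3ccc(-c4ccccn4)cc3)nc(SC3CCCC3O)nc12` gives 567 nM in a functional assay on HT cells (Homo sapiens) for antiproliferative activity, read by fluorescence, with a stated time of 72 h; a higher number here means a weaker inhibitor of growth, a lower number a stronger inhibitor of growth. Within the data shown here, its only comparison is compound 1 `CC(C)c1n[nH]c2c(NCc3ccc(-c4ccccn4)cc3)nc(SCC(N)CN)nc12`, which gives 480 nM; the two numbers sit within the scatter of one another, as the step of a 1.2-fold higher number from compound 1 to compound 2 (0.07 log units; within the scatter) shows. Compound 3 `CCC(CO)Sc1nc(NCc2ccc(-c3ccccn3)cc2)c2[nH]nc(C(C)C)c2n1` differs from compound 2 by one change (1-(hydroxymethyl)propyl in place of 2-hydroxycyclopentyl on a sulfur). Among the measured compounds shown here, the one step that bears on this change is that same swap of the group on the sulfur, and it moved the number little. The step is therefore expected to be a 1.0-fold lower number from compound 2 to compound 3 (0.01 log units; within the scatter), with no change beyond the scatter. Compound 3 is estimated at 550 nM, between 250 nM and 1200 nM.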

Compound 3, concentration for 50% growth inhibition: 255 nM
Compound 3: middle estimate off by 2.2-fold (0.33 log units), on the high side; low and high end bracket the measured number.
By their numbers in this assay, from the lowest: compounds 3, 1 and 2 (each within the scatter of the next, the first and the last beyond it).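

Swapping the ring for an open chain on the sulfur can shift the number beyond the scatter: 1-(hydroxymethyl)propyl in place of 2-hydroxycyclopentyl gives a modest step (a 2.2-fold lower number from compound 2 to compound 3 (0.35 log units; beyond the scatter)) in this assay. The step against 2,3-diaminopropyl (a 1.9-fold lower number from compound 1 to compound 3 (0.27 log units; within the scatter)) stays within the scatter, so those two groups cannot be told apart here. No evidence is available to explain the difference between the ring and the chain. Still open, going by these compounds, is whether the hydroxyl is needed, which a plain butyl chain would test, and how a carboxylic acid on the sulfur would behave.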